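The source may hold more compounds than are shown below. What is called first, only, known or untested is meant among the compounds shown, and "the series" means these compounds.

Compound 1 `Cc1cccc(Cn2cc(CCCCC[C@@H]3SC[C@@H]4NC(=O)N[C@@H]43)nn2)c1` and compound 2 `O=C1N[C@H]2[C@H](CS[C@H]2CCCCCc2cn(Cc3cccc(C(F)(F)F)c3)nn2)N1` share one core and differ only in the group on the benzylic ring. In an assay on isolated protein for inhibition of biotin--protein ligase (Homo sapiens), read by scintillation counting, with a stated time of 10 min (a lower number here means a stronger inhibitor, a higher number a weaker inhibitor), compound 1 gives only a limit of the assay, > 16000 nM. In this assay compound 2 also gives only a limit, > 16000 nM. The step that the two limits leave unreadable from compound 1 to compound 2 cannot be read because of the limit of > 16000 nM in this assay, at which 2 of the 2 values shown sit. Compound 3 `O=C1N[C@H]2[C@H](CS[C@H]2CCCCCc2cn(Cc3ccc(C(F)(F)F)cc3)nn2)N1` differs from compound 2 by 4-(trifluoromethyl)phenyl in place of 3-(trifluoromethyl)phenyl on a saturated chain carbon bound to an aromatic nitrogen. Within the data shown here, no measured step bears on this change. Compound 3 is expected to remain at the limit, so the estimated step that the limit leaves unreadable from compound 2 to compound 3 means no change beyond the scatter. Compound 3 is estimated at 30000 nM, between 8000 nM and 120000 nM.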

Compound 3, inhibition constant: > 16000 nM
Compound 3 ended at the assay's limit; the forecaster's own chance of this, stated with the estimate: 80%; the middle value is on the limit's open side.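

Compound 3 gives only a limit of the assay in this assay, > 16000 nM, so its steps from compound 1 and compound 2 cannot be read: the limit of > 16000 nM in this assay, at which 3 of the 3 values shown sit. The compounds shown leave open how strongly each inhibits the enzyme, and whether these group changes alter that at all.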